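A Methoxy for a Trifluoromethyl: Little Change Expected

This account rests on a few compounds, and the source may have more. Where it says the series, first, only, none or still open, it means among the compounds named here.

In an ADME assay on HaCaT cells (Homo sapiens) for inhibition, read by sulforhodamine B assay, with a stated time of 48 h (on this read-out lower numbers stand for stronger inhibition of growth and higher numbers for weaker inhibition of growth), compound 1 `O=C1C=COC(/C=C/c2ccccc2)C1` gives 127 uM and compound 2 `O=C1C=COC(/C=C/c2ccc(C(F)(F)F)cc2)C1` gives 123 uM. Compound 2 has the lower of the two numbers, yet a 1.0-fold lower number from compound 1 to compound 2 (0.01 log units; within the scatter), so the two cannot be told apart. Compound 3 `COc1ccc(/C=C/C2CC(=O)C=CO2)cc1` differs from compound 2 by methoxy in place of trifluoromethyl on an aromatic carbon. Among the compounds with values here, no measured step exchanges these two groups; the only step seen, which also changes the group on an aromatic carbon, stayed within the scatter, so no change beyond the scatter is expected from compound 2 to compound 3, namely a 1.0-fold higher number from compound 2 to compound 3 (0.01 log units; within the scatter). Compound 3 is therefore estimated at 125 uM, within a range from 60 uM to 260 uM.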

Compound 3, concentration for growth inhibition (reported as GI): 145 uM
Beside the measured number, compound 3's estimate is 1.2-fold (0.06 log units) below it; the measured number falls inside the stated range.
By their numbers in this assay, from the lowest: compounds 2, 1 and 3 (each within the scatter of the next).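

In this assay, methoxy in place of trifluoromethyl gives a 1.2-fold higher number from compound 2 to compound 3 (0.07 log units; within the scatter), and methoxy in place of hydrogen gives a 1.1-fold higher number from compound 1 to compound 3 (0.06 log units; within the scatter). Hydrogen, trifluoromethyl and methoxy at this position therefore cannot be told apart, even though methoxy brings a hydrogen-bond acceptor that the other two lack. Nothing available gives a reason for this flat result.

On these data alone, whether an amine, a carboxylic acid or a longer chain at this position would move the number beyond the scatter remains open. So does the effect of a change elsewhere on the shared core.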